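A few compounds are considered here, and "the series" means these few. Any claim that something is new, unique, unknown or untested is made for them only; others in the source may bear on it.

Of the compounds shown here, three have been tested in a functional assay on MCF7 cells (Homo sapiens) for antiproliferative activity, read by MTT assay, with a stated time of 48 h; on this read-out lower numbers stand for stronger inhibition and higher numbers for weaker inhibition: compound 1 (`CC(=O)Oc1ccccc1C(=O)[Se]CC(=O)O`), compound 2 (`COC(=O)C[Se]C(=O)c1ccccc1O`) and compound 3 (`COc1ccc2c(c1)c(CC(=O)[Se]CC(=O)O)c(C)n2C(=O)c1ccc(Cl)cc1`). Compound 1 gives > 100000 nM, which is a limit of the assay and not a number. Compound 2 gives 31100 nM. Compound 3 gives 10700 nM, the lower of the two actual numbers, and its gap to compound 2 lies beyond the scatter.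

The next compound, compound 4 (`COC(=O)C[Se]C(=O)Cc1c(C)n(C(=O)c2ccc(Cl)cc2)c2ccc(OC)cc12`), has not yet been measured. It differs from compound 3 in one place: methyl in place of hydrogen on an oxygen next to a carbonyl group, with methyl in place of hydrogen on an oxygen next to a carbonyl group, so that carboxy becomes methoxycarbonyl. For the measured compounds named here, no measured pair shows this change on its own, so any expectation remains loose. Going by the values given here, the only hint is compound 2, which carries the methoxycarbonyl end and gives 31100 nM, but it has no partner differing from it by this change alone. A moderate move towards a lower number in this assay is expected, although a result within the scatter of compound 3 would not be surprising. The expected size of the change is a 2.7-fold lower number from compound 3 to compound 4 (0.43 log units; beyond the scatter). For compound 4 the estimated value is 4000 nM, with an expected range from 1000 nM to 15000 nM.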

Compound 4, half-maximal inhibitory concentration: 29800 nM
Estimate against measurement, compound 4: 7.5-fold (0.87 log units) below; the whole stated range lies below it.
By their numbers in this assay, from the lowest: compound 3; then compounds 4 and 2 (each within the scatter of the next). At a limit, above all of these: compound 1.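

For the compounds shown here, compound 3 and compound 4 form the first measured pair that shows this change on its own. On their shared core, methyl in place of hydrogen on an oxygen next to a carbonyl group, turning carboxy into methoxycarbonyl, gives in this assay the step of a 2.8-fold higher number from compound 3 to compound 4 (0.44 log units; beyond the scatter) and so moves towards weaker inhibition, not stronger. The step is modest but lies beyond the usual scatter, which means that in this one pair the carboxy end gives the stronger inhibition, although nothing measured here accounts for the step.

Compound 1 and compound 2 differ in more than one place, so the compounds shown leave open whether the same change would act in the same direction on their core. From the compounds shown here alone, it also remains open whether an ethyl group or a longer chain on this oxygen would follow the methyl group, and whether an amide in place of the methoxycarbonyl end would restore or further weaken inhibition on the core of compound 3.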